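Removing the methylcarbamoyl group: half-life of compound 4

This account rests on a few compounds, and the source may have more. Where it says the series, first, only, none or still open, it means among the compounds named here.

Compound 1 `CCCCN(c1nc2c(C(=O)NC)cccc2o1)[C@H](C)c1ccc(-c2ccccc2-c2nnn[nH]2)cc1`: 1.3 h
Compound 2 `C[C@H](c1ccc(-c2cc(F)ccc2-c2nc(=O)o[nH]2)cc1)N(CC1CC1)c1nc2c(C(=O)O)cccc2o1`: 4.1 h
Compound 3 `CCCCN(c1nc2c(C(=O)O)cccc2o1)[C@H](C)c1ccc(-c2cc(F)ccc2-c2nc(=O)o[nH]2)cc1`: 2.2 h

Of the compounds shown here, three have been measured in an ADME assay on the whole organism (Macaca fascicularis) for metabolic stability, read by LC-MS, using cassette dosing, at a dose of 1 mg/kg by the oral route; a higher number here means that the compound lasts longer, a lower number that the compound disappears faster. Compound 1 gives 1.3 h, the lowest of the three numbers: the gap to compound 3 is within the scatter, while the gap to compound 2 lies beyond it. For the measured compounds named here, the only single-point step among the measured compounds is a 1.9-fold lower number from compound 2 to compound 3 (0.27 log units; within the scatter), which concerns the chain on the nitrogen and not the part of the core that changes here.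

Compound 4 `CCCCN(c1nc2ccccc2o1)[C@H](C)c1ccc(-c2ccccc2-c2nnn[nH]2)cc1` differs from compound 1 in one place: hydrogen in place of methylcarbamoyl on an aromatic carbon. Going by the values given here, no measured pair shows this change, so no precedent fixes its size or direction in this assay. With nothing pointing either way, the expectation for compound 4 is a number close to that of compound 1, and the step from compound 1 to compound 4 is expected to be a 1.1-fold lower number from compound 1 to compound 4 (0.03 log units; within the scatter). The estimated half-life for compound 4 is therefore 1.2 h, with a range from 0.5 h to 3 h.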

Compound 4, half-life: 3.2 h
Compound 4: middle estimate off by 2.7-fold (0.43 log units), on the low side; the whole stated range lies below it.
By their numbers in this assay, from the lowest: compounds 1, 3, 4 and 2 (each within the scatter of the next, the first and the last beyond it).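

In this assay, for the compounds shown here, hydrogen in place of methylcarbamoyl on an aromatic carbon of the shared core gives a 2.5-fold higher number from compound 1 to compound 4 (0.39 log units; beyond the scatter), the first step at this position, and it lies beyond the scatter. The half-life therefore responds to what sits at this place, and the methylcarbamoyl group is not required for the compound to last, at least with this butyl chain and this tetrazole-bearing biaryl. Nothing at hand gives a reason for the step.

What the compounds shown leave open is how a different group at this place, such as an amine or a nitrile, would compare with hydrogen. On these data alone, it also remains open whether removing the carboxylic acid of compound 2 or compound 3 would give a step of similar size and direction.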